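Sulfonylpyridopyrimidinones on DU-145 cells: carboxy to fluoro

This account rests on a few compounds, and the source may have more. Where it says the series, first, only, none or still open, it means among the compounds named here.

Measured so far:
compound 1, `Cn1c(=O)c(S(=O)(=O)c2ccc(C(=O)O)cc2)cc2cnc(Nc3ccc4[nH]ccc4c3)nc21`, 10000 nM in a functional assay on DU-145 cells (Homo sapiens) for inhibition, read by trypan blue exclusion, with a stated time of 72 h; a higher number here means a weaker inhibitor, a lower number a stronger inhibitor
compound 2, `Cn1c(=O)c(S(=O)(=O)c2ccc(F)cc2F)cc2cnc(Nc3cnc4[nH]ccc4c3)nc21`, 750 nM in this assay

Compound 1 carries the highest of the two numbers; compound 2 sits well below it, and the gap between them lies beyond the scatter. Among the compounds with values here, the two differ in more than one place, so no single step between them is counted here.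

Compound 3, `Cn1c(=O)c(S(=O)(=O)c2ccc(F)cc2)cc2cnc(Nc3ccc4[nH]ccc4c3)nc21`, remains to be measured in this assay. It differs from compound 1 in one place only: fluoro in place of carboxy on an aromatic carbon, on an aromatic carbon of a six-membered aromatic ring of carbon only, para to a large group; cut one bond further out, the change reads 4-carboxyphenyl to 4-fluorophenyl.

Within the data shown here, no measured pair shows this exact step. Among the measured compounds shown here, the only other fluoro-bearing compound, compound 2, gives the lower number, but it also differs elsewhere, so it gives no clean guide. Compound 3 is nonetheless expected to move toward a lower number, a step of a 5.6-fold lower number from compound 1 to compound 3 (0.74 log units; beyond the scatter), with the result expected around 1800 nM, between 450 nM and 7000 nM.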

Compound 3, half-maximal inhibitory concentration: 300 nM
Estimate against measurement, compound 3: 6.0-fold (0.78 log units) above; measured number below the stated range.
By their numbers in this assay, from the lowest: compound 3; then compound 2; then compound 1.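

Within the data shown here, the step 4-carboxyphenyl to 4-fluorophenyl gives a 33-fold lower number from compound 1 to compound 3 (1.52 log units; beyond the scatter) in this assay, the first comparison that changes one place only. On a shared core, the group on this aromatic carbon, para to a large group, can therefore move the number far beyond the scatter. Nothing at hand says why the number moves.

A compound with hydrogen, chloro or a methyl ester at this carbon would show whether the step follows from the loss of carboxy or from the arrival of fluoro. On these data alone, compound 2 differs from compound 3 in more than one place, so steps involving compound 2 cannot be read, and the effect of a second fluoro on this ring stays open.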